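A few compounds are considered here, and "the series" means these few. Any claim that something is new, unique, unknown or untested is made for them only; others in the source may bear on it.

Compound 3, `Cc1cccc(C#Cc2ccc(C(=O)N[C@H](C)C(C)(C)O)nc2)c1`, reaches 68.6% in a functional assay on HEK293 cells for positive allosteric modulation of metabotropic glutamate receptor 5 (Rattus norvegicus), read by fluorescence and calcium flux; a lower number here means a smaller maximal response, a higher number a larger maximal response. Its two companions sit close by: compound 1, `C[C@@H](NC(=O)c1ccc(C#Cc2ccccc2F)cn1)C(C)(C)O`, gives 60%, and compound 2, `C[C@@H](NC(=O)c1ccc(C#Cc2ccc(F)cc2F)cn1)C(C)(C)O`, gives 61.2%. The gaps among the three are all inside the usual scatter, so compound 3 holds the largest number only on paper: the step of a number 8.6 percentage points higher from compound 1 to compound 3 (within the scatter) and the step of a number 7.4 percentage points higher from compound 2 to compound 3 (within the scatter) both fall within the scatter, as does the step of a number 1.2 percentage points higher from compound 1 to compound 2 (within the scatter).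

Compound 4 is `C[C@@H](NC(=O)c1ccc(C#Cc2cccc(F)n2)cn1)C(C)(C)O`. Its difference from compound 3 is 6-fluoropyridin-2-yl in place of 3-methylphenyl on a triple-bonded carbon. The ring attached to the triple-bonded carbon is swapped as a whole, with one ring atom becoming nitrogen and a fluorine entering in place of the methyl.

Within the data shown here, the steps that bear on this change are the two earlier swaps of the same ring, from compound 1 and from compound 2 to compound 3, and both stayed within the scatter. Among the measured compounds shown here, no measured step puts a nitrogen into that ring, so the new ring atom is untested here. On the evidence of the two ring swaps already seen, the step of a number 6.6 percentage points lower from compound 3 to compound 4 (within the scatter) is expected to be small and to stay within the scatter. For compound 4 the estimated maximal response is 62%, with a likely range from 45% to 78%.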

Compound 4, largest response reached (reported as efficacy), in percent of the reference or control that the assay uses: 63%
Beside the measured number, compound 4's estimate is 1 percentage points below it; the range from low to high includes it.
By their numbers in this assay, from the lowest: compounds 1, 2, 4 and 3 (each within the scatter of the next).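

On the triple-bonded carbon, 6-fluoropyridin-2-yl gives the first ring here with a nitrogen among its ring atoms and a hydrogen-bond acceptor, and in this assay the step to it from 3-methylphenyl is a number 5.6 percentage points lower from compound 3 to compound 4 (within the scatter). The comparisons with the two fluorinated phenyl rings agree, with a number 1.8 percentage points higher from compound 2 to compound 4 (within the scatter) and a number 3 percentage points higher from compound 1 to compound 4 (within the scatter), so in this set of compounds the ring with a nitrogen cannot be told apart from the rings of carbon only by their maximal response. No measurement presented here offers a reason for this result.

The nitrogen and the fluorine entered together, so a plain pyridin-2-yl ring would be needed to show what each contributes on its own. From the compounds shown here alone, it also remains open whether a ring carrying an amine or a carboxylic acid, or a saturated ring such as cyclohexyl on the triple-bonded carbon, would keep the maximal response in this same narrow band or move it beyond the scatter.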